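Swapping the pyrazole substituents on compound 2

The source may hold more compounds than are shown below. What is called first, only, known or untested is meant among the compounds shown, and "the series" means these compounds.

Of the compounds shown here, two have been measured in an ADME assay on microsomes from liver (Homo sapiens) for pharmacokinetics; on this read-out lower numbers stand for slow clearance and higher numbers for fast clearance. Compound 1 `C[C@@H]1CCCN1c1c(C#N)c2c(N)nc(Nc3cn(C)nc3Cl)nc2n1C` gives 183 mL/min/kg, and compound 2 `C[C@@H]1CCCN1c1c(C#N)c2c(N)nc(Nc3cn(C)nc3C(F)(F)F)nc2n1C` gives 33.3 mL/min/kg. For the measured compounds named here, compound 2 therefore stands at the lowest of the two numbers, with compound 1 as its nearest neighbour at a higher value; the one measured step, a 5.5-fold lower number from compound 1 to compound 2 (0.74 log units; beyond the scatter), is the only comparison available.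

Compound 3 `Cc1c(Nc2nc(N)c3c(C#N)c(N4CCC[C@H]4C)n(C)c3n2)cnn1C1COC1` has not yet been measured in this assay. It differs from compound 2 by 5-methyl-1-(oxetan-3-yl)-1H-pyrazol-4-yl in place of 1-methyl-3-(trifluoromethyl)-1H-pyrazol-4-yl on a nitrogen on an aromatic ring. Going by the values given here, no measured step covers this kind of change; the step from compound 1 to compound 2 concerns a different exchange on the same ring and does not bear on it directly. Without a precedent, the expected step of a 1.2-fold higher number from compound 2 to compound 3 (0.08 log units; within the scatter) is put at none beyond the scatter, though the range is wide. Compound 3 is thus estimated at 40 mL/min/kg, within 15 mL/min/kg to 110 mL/min/kg.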

Compound 3, clearance: 14.3 mL/min/kg
Compound 3: the middle estimate sits 2.8-fold (0.45 log units) above what was measured, and the stated range ends above it.
By their numbers in this assay, from the lowest: compound 3; then compound 2; then compound 1.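

In this assay, 5-methyl-1-(oxetan-3-yl)-1H-pyrazol-4-yl in place of 1-methyl-3-(trifluoromethyl)-1H-pyrazol-4-yl gives a 2.3-fold lower number from compound 2 to compound 3 (0.37 log units; beyond the scatter). The number at this position can therefore still fall after the trifluoromethyl group has gone, with a substituent that holds neither fluorine nor chlorine. Set against the chloro group, the same entering group gives a 13-fold lower number from compound 1 to compound 3 (1.11 log units; beyond the scatter), a large step. Nothing available explains why the number falls.

The exchange alters the pyrazole in more than one way at once, so the compounds shown cannot tell whether the oxetane, the 5-methyl or the loss of trifluoromethyl carries the step. Going by these compounds, it also remains open whether an azetidine or an open-chain methoxyethyl group in place of the oxetane would give a similar number.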